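Trifluoromethoxy in place of iodo: expected potency

A few compounds are considered here, and "the series" means these few. Any claim that something is new, unique, unknown or untested is made for them only; others in the source may bear on it.

Measured so far:
compound 1, `C#CCOc1ccc(C(C)(C)C)cc1C1(c2ccccc2)C(=O)Nc2ccccc21`, in a functional assay on CRL2813 cells (Homo sapiens) for antiproliferative activity, read by sulforhodamine B assay, with a stated time of 5 days (a lower number here means a stronger inhibitor, a higher number a weaker inhibitor), gives only a limit, > 20000 nM.
compound 2, `CC(C)(C)c1ccc(O)c(C2(c3ccccc3)C(=O)Nc3ccc(I)cc32)c1`, in this assay gives 2800 nM.

Compound 2 holds the only plain number shown; the other entry is a limit, (the limit of > 20000 nM in this assay, at which 1 of the 2 values shown sits). Compound 3, `CC(C)(C)c1ccc(O)c(C2(c3ccccc3)C(=O)Nc3ccc(OC(F)(F)F)cc32)c1`, differs from compound 2 by trifluoromethoxy in place of iodo on an aromatic carbon. Among the compounds with values here, no step between two measured compounds is available, so the change is untested here. The step from compound 2 to compound 3 is expected to be small, within the usual scatter, no change at the digits printed from compound 2 to compound 3 (within the scatter). Compound 3 is estimated at 2800 nM, ranging from 900 nM to 9000 nM.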

Compound 3, half-maximal inhibitory concentration: 1000 nM
The estimate for compound 3 lay 2.8-fold (0.45 log units) above the measured number, within the range that was stated.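

Trifluoromethoxy in place of iodo on this aromatic carbon gives a 2.8-fold lower number from compound 2 to compound 3 (0.45 log units; beyond the scatter) in this assay and is the first change read at this position. The position therefore accepts a swap from a single halogen atom to a larger oxygen-linked group with no loss of potency, and the step is modest. No measured property shown here bears on this step. Two substituents at one position define no trend. Going by these compounds, whether a nitrile or an amine on this carbon would move the number in the same direction remains open.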